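The source may report more compounds than this note shows. Statements on the series, on what has been measured and on what is new or still open speak of the compounds shown alone.

In a functional assay on L1210 cells (Mus musculus) for inhibition, read by cell counting, with a stated time of 2 days (a higher number here means a weaker inhibitor, a lower number a stronger inhibitor), three compounds have been measured. Compound 3 `C=C(Br)C(=O)Nc1cccc(-c2cn3nc(-c4ccc(OC)c(OC)c4)sc3n2)c1` gives 42 nM. Compound 1 `C=C(Br)C(=O)Nc1cccc(-c2cn3nc(-c4cccc(OC)c4)sc3n2)c1` gives 580 nM. The two differ by hydrogen in place of methoxy on an aromatic carbon, and the step is a 14-fold higher number from compound 3 to compound 1 (1.14 log units; beyond the scatter). Compound 2 `COc1cccc(-c2nn3cc(-c4cccc(N)c4)nc3s2)c1` reaches only a limit of this assay, > 250000 nM. From compound 1 the step is an at least 430-fold higher number from compound 1 to compound 2 (2.63 log units; beyond the scatter), with hydrogen in place of (1-bromoethenyl)carbonyl on a nitrogen on an aromatic ring. The difference between the cores of compound 2 and compound 3 is not broken down here.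

Compound 4 `Nc1cccc(-c2cn3nc(-c4ccccc4)sc3n2)c1` has not yet been measured in this assay. It differs from compound 2 by hydrogen in place of methoxy on an aromatic carbon. Within the data shown here, this is the same kind of change as the one from compound 3 to compound 1, but not the same: there the site was ortho to a methoxy group and para to a large group, here it is meta to a large group. Compound 2 already sits at the limit. The step of a 14-fold higher number from compound 3 to compound 1 (1.14 log units; beyond the scatter) also moved toward a higher number. Compound 4 is therefore expected near 300000 nM, between 100000 nM and 1000000 nM, most likely again a limit. The expected step is a step that the limit leaves unreadable from compound 2 to compound 4.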

Compound 4, half-maximal inhibitory concentration: 32000 nM
Estimate against measurement, compound 4: 9.4-fold (0.97 log units) above; measured number outside the range, below it.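

In this assay, the removal of a methoxy group did not carry over from one core to the other, and the two steps run in opposite directions: the same change on two cores in this assay, a 14-fold higher number (1.14 log units; beyond the scatter) from compound 3 to compound 1 and an at least 7.8-fold lower number (0.89 log units; beyond the scatter) from compound 2 to compound 4, at least 100-fold (2.03 log units) apart, beyond the scatter of two such steps

The new step, an at least 7.8-fold lower number from compound 2 to compound 4 (0.89 log units; beyond the scatter), belongs to a pair with a free amine, whereas the earlier pair carries the (1-bromoethenyl)carbonyl on its nitrogen and loses its methoxy from a different place, so these compounds do not show which of these differences separates the two results. Compound 2 is only a limit of the assay, not a number: the limit of > 250000 nM in this assay, at which 1 of the 4 values shown sits.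

The compounds shown leave open whether the opposite directions persist when the methoxy gives way to a group other than hydrogen, such as an ethoxy or a fluorine. They also leave open how the change behaves when an acetyl stands on the nitrogen in place of the (1-bromoethenyl)carbonyl.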